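This account rests on a few compounds, and the source may have more. Where it says the series, first, only, none or still open, it means among the compounds named here.

Three compounds that share one core and differ only in the group on an amide-type nitrogen have been tested in a functional assay on CLL cells (Homo sapiens) for cytotoxicity, read by MTT assay, with a stated time of 48 h; on this read-out higher numbers stand for an effect only at larger amounts of compound and lower numbers for an effect already at smaller amounts. There, compound 1 `C=C(CC)C(=O)c1ccc(OCC(=O)Nc2nc3ccccc3s2)c(Cl)c1Cl` gives 1500 nM, compound 2 `C=C(CC)C(=O)c1ccc(OCC(=O)Nc2ccc(C(=O)O)cc2)c(Cl)c1Cl` gives 5000 nM, and compound 3 `C=C(CC)C(=O)c1ccc(OCC(=O)Nc2ccc3nc[nH]c3c2)c(Cl)c1Cl` gives 3200 nM. Compound 3 therefore stands close to compound 2 and apart from compound 1: the numbers show a 1.6-fold lower number from compound 2 to compound 3 (0.19 log units; within the scatter), and also a 2.1-fold higher number from compound 1 to compound 3 (0.33 log units; beyond the scatter).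

Compound 4 `C=C(CC)C(=O)c1ccc(OCC(=O)Nc2ccc(O)c(Cl)c2)c(Cl)c1Cl` keeps the core and changes that same group: 3-chloro-4-hydroxyphenyl in place of 1H-benzimidazol-6-yl on an amide-type nitrogen. In words, 3-chloro-4-hydroxyphenyl takes the place of 1H-benzimidazol-6-yl.

All three measured steps change this group, so all of them bear on the new one. They are small, and the largest is a 3.3-fold higher number from compound 1 to compound 2 (0.52 log units; beyond the scatter). For the measured compounds named here, no tested compound carries 3-chloro-4-hydroxyphenyl, so the data give no direction, and no step beyond the scatter is expected in this assay. The expected change is a 1.1-fold lower number from compound 3 to compound 4 (0.03 log units; within the scatter). For compound 4 the estimated value is 3000 nM, with an expected range from 1300 nM to 7000 nM.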

Compound 4, half-maximal effective concentration: 5500 nM
For compound 4 the middle estimate is 1.8-fold (0.26 log units) below the measured one; the range from low to high includes it.
By their numbers in this assay, from the lowest: compound 1; then compounds 3, 2 and 4 (each within the scatter of the next).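

In this assay a third type of group on an amide-type nitrogen, 3-chloro-4-hydroxyphenyl, gives a number that cannot be separated from those of the two nearest compounds: the steps are a 1.7-fold higher number from compound 3 to compound 4 (0.24 log units; within the scatter) and a 1.1-fold higher number from compound 2 to compound 4 (0.04 log units; within the scatter) on the same read-out. The gap to the 1,3-benzothiazol-2-yl group remains clear, with a 3.7-fold higher number from compound 1 to compound 4 (0.56 log units; beyond the scatter) as the new step, so compound 1 now stands apart from all three other compounds. No measurement at hand says what lies behind this grouping.

From the compounds shown here alone, whether the chlorine or the hydroxyl of the new group matters on its own stays open, since neither appears here without the other. Also open, going by these compounds, is how a plain phenyl, an amine or a longer alkyl chain on that nitrogen would compare with compound 1 and the other three.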